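The source may report more compounds than this note shows. Statements on the series, on what has been measured and on what is new or still open speak of the compounds shown alone.

The measured compounds:

Compound 1, `O=S(=O)(NCc1csc2ccccc12)c1ccc(Br)cc1`, gives 87100 nM in an ADME assay on MDCK cells (Canis lupus familiaris) for cytotoxicity, read by MTT assay, with a stated time of 24 h; a higher number here means that more compound is tolerated, a lower number that less compound is tolerated.
Compound 2, `O=S(=O)(NCc1csc2ccccc12)c1ccc(C(F)(F)F)cc1`, gives 94800 nM in this assay.
Compound 3, `O=S(=O)(NCc1cc2ccccc2s1)c1ccc(Br)cc1`, gives only a limit in this assay, reported as > 174000 nM.

Compounds 1 and 2 share one core and differ in a single place: trifluoromethyl in place of bromo on an aromatic carbon. In this assay this change made a 1.1-fold higher number from compound 1 to compound 2 (0.04 log units; within the scatter), so the two compounds are indistinguishable there. Compound 3 is built from the same atoms as compound 1, joined differently; how the two cores differ is not broken down here. For compound 3 the read-out is a limit of the assay and not a number, namely (the limit of > 174000 nM in this assay, at which 1 of the 3 values shown sits).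

Compound 4, `O=S(=O)(NCc1cc2ccccc2s1)c1ccc(C(F)(F)F)cc1`, has not yet been measured. It relates to compound 3 exactly as compound 2 relates to compound 1, through the same change at the same place: trifluoromethyl in place of bromo on an aromatic carbon. Going by the values given here, the one measured instance of this change, a 1.1-fold higher number from compound 1 to compound 2 (0.04 log units; within the scatter), was within the scatter, so the step from compound 3 to compound 4 is also expected to be small, a step that the limit leaves unreadable from compound 3 to compound 4. Because compound 3 itself sits at the limit of > 174000 nM in this assay, at which 1 of the 3 values shown sits, compound 4 is expected to lie at or beyond that limit as well, and the assay may again report only a limit. Compound 4 is therefore estimated at 200000 nM, with the expected range running from 100000 nM to 400000 nM.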

Compound 4, half-maximal cytotoxic concentration: > 179000 nM
Compound 4: no number, only a limit; the forecaster's own chance of this, stated with the estimate: 70%; the middle value lies beyond the limit too.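

In this assay, going by these compounds alone, compound 3 and compound 4 both give only a limit and no number, so no step between the two can be read. The compounds shown leave open where either compound truly lies, and whether trifluoromethyl in place of bromo on an aromatic carbon matters as little on the core of compound 3 as it does on the core of compound 1.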